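Triazole aryl swap on a prenylated flavanone oxime ether

The source may report more compounds than this note shows. Statements on the series, on what has been measured and on what is new or still open speak of the compounds shown alone.

Compound 1 `COc1cc2c(cc1CC=C(C)C)/C(=N/NC(N)=O)C[C@@H](c1ccc(O)cc1)O2` gives 87% in a functional assay on HCT-116 cells (Homo sapiens) for inhibition, read by sulforhodamine B assay, with a stated time of 48 h, tested at 50 uM; on this read-out lower numbers stand for less inhibition of growth and higher numbers for more inhibition of growth at the one concentration tested. Compound 2 `COc1ccc([C@@H]2C/C(=N/OCc3cn(-c4ccc(Cl)cc4C)nn3)c3cc(CC=C(C)C)c(OC)cc3O2)cc1` stands lowest of the two measured compounds, giving 20% in this assay, a gap to compound 1 that lies beyond the scatter. Compound 3 `COc1ccc([C@@H]2C/C(=N/OCc3cn(-c4ccccc4CO)nn3)c3cc(CC=C(C)C)c(OC)cc3O2)cc1` differs from compound 2 in one place: 2-(hydroxymethyl)phenyl in place of 4-chloro-2-methylphenyl on an aromatic nitrogen. Going by the values given here, no measured pair shows this change, so its effect in this assay is unknown. The step of a number 5 percentage points higher from compound 2 to compound 3 (within the scatter) is expected to be small, with no direction beyond the scatter. Compound 3 is therefore expected to give 25% in this assay, within 5% to 55%.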

Compound 3, percent growth inhibition at one concentration: 100%
Compound 3: middle estimate off by 75 percentage points, on the low side, outside the stated range (above it).
By their numbers in this assay, from the lowest: compound 2; then compound 1; then compound 3.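

In this assay, the group on the aromatic nitrogen proves decisive: 2-(hydroxymethyl)phenyl in place of 4-chloro-2-methylphenyl gives a number 80 percentage points higher from compound 2 to compound 3 (beyond the scatter) at the one concentration tested. The swap keeps the heavy-atom count and the six-membered aromatic ring, but chlorine leaves and oxygen enters, adding 1 hydrogen-bond donor and 1 hydrogen-bond acceptor. Nothing available explains why the number moves this far.

Going by these compounds, whether the hydroxymethyl or the loss of the chlorine and methyl carries the step remains open. So does how an aminomethyl, a carboxylic acid or a longer hydroxyalkyl chain would behave in place of the hydroxymethyl.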